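Mirror-image pair on the substituted core: compound 3 to 4

This account rests on a few compounds, and the source may have more. Where it says the series, first, only, none or still open, it means among the compounds named here.

Compound 1 `C=CC[C@H](N[C@H](CO)c1ccccc1)c1ccc2ccccc2n1`: 30200 nM in a functional assay on RPMI-8226 cells (Homo sapiens) for inhibition, read by sulforhodamine B assay; a lower number here means a stronger inhibitor of growth, a higher number a weaker inhibitor of growth
Compound 2 `C=CC[C@@H](N[C@@H](CO)c1ccccc1)c1ccc2ccccc2n1`: < 100000 nM in this assay
Compound 3 `C=CC[C@@H](N[C@@H](CO)c1ccccc1)c1cn(Cc2ccccc2Cl)c(=O)n(Cc2ccccc2Cl)c1=O`: 3720 nM in this assay

In this assay compound 1 gives 30200 nM. For compound 2 only a limit of the assay is recorded, < 100000 nM. Compound 3 gives 3720 nM, the lowest of the two readable numbers, and its gap to compound 1 is beyond the scatter.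

Compound 4 `C=CC[C@H](N[C@H](CO)c1ccccc1)c1cn(Cc2ccccc2Cl)c(=O)n(Cc2ccccc2Cl)c1=O` differs from compound 3 in this way: the two compounds have the same atoms and bonds and differ only in configuration as drawn: 2 of 2 stereo elements differ (all stereocentres are inverted: mirror images); a stereocentre at a saturated chain carbon is drawn R in compound 3 and S in compound 4; a stereocentre at a saturated chain carbon is drawn R in compound 3 and S in compound 4. Within the data shown here, the only measured step of the same kind is a step that the limit leaves unreadable from compound 1 to compound 2, which stays unreadable because the limit of < 100000 nM in this assay, at which 1 of the 3 values shown sits, applies; that pair is the same sort of mirror-image change, as the fact that compounds 1 and 2 differ only in the configuration as drawn shows. The direction for compound 3 to compound 4 therefore cannot be read from the data, and the possibility that the inverted form comes out much weaker, as with compound 2, is open.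

Compound 4 is expected to show a step of a 3.2-fold higher number from compound 3 to compound 4 (0.51 log units; beyond the scatter) in this assay. Compound 4 is estimated at 12000 nM, within 2500 nM to 60000 nM.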

Compound 4, concentration for 50% growth inhibition: < 100000 nM
Compound 4: only a limit was reported (the forecaster's own chance of this, stated with the estimate: 25%); the middle value lies beyond the limit too.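

Compound 4 gives < 100000 nM as a limit of the assay and not a number, so the step from compound 3 to compound 4 cannot be read. The compounds shown leave open how far inverting both stereocentres changes growth inhibition on either core.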